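Butyl for Methoxy: Expected Effect in the Rat

The source may report more compounds than this note shows. Statements on the series, on what has been measured and on what is new or still open speak of the compounds shown alone.

Compound 1 `COc1ccc2ncc(-c3nn[nH]n3)cc2c1` and compound 2 `Fc1cc(F)c2ncc(-c3nn[nH]n3)cc2c1` share a core and were both examined in a functional assay on the whole organism (strain Sprague-Dawley) for inhibition, with Rattus norvegicus as the target; a higher number here means that more compound is needed for the effect, a lower number that less compound is needed. Compound 1 reaches only a limit of that assay, > 25 mg/kg. Compound 2 likewise reaches only a limit in this assay, > 50 mg/kg. Among the compounds with values here, compound 1 therefore stands on no firm number; the single other value shown is a limit as well, the limit of > 25 mg/kg in this assay, at which 1 of the 2 values shown sits, and the limit of > 50 mg/kg in this assay, at which 1 of the 2 values shown sits, being the whole of the evidence, so no order between the two can be drawn.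

Compound 3 `CCCCc1ccc2ncc(-c3nn[nH]n3)cc2c1` differs from compound 1 in one place: butyl in place of methoxy on an aromatic carbon. Within the data shown here, no step between measured compounds exists to guide the size of the change. Nothing in the two limits supports a shift beyond the usual scatter in this assay, so the step from compound 1 to compound 3 is expected to be small, a step that the limit leaves unreadable from compound 1 to compound 3. Compound 3 is estimated to give 30 mg/kg in this assay, within 10 mg/kg to 100 mg/kg, most likely reported again only as a limit.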

Compound 3, minimum effective dose: > 25 mg/kg
Compound 3 gave a limit, no number; the forecaster's own chance of this, stated with the estimate: 70%; the middle value does not contradict the limit.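

Compound 1 and compound 3 both stand only on limits in this assay, so no step between them can be read: the limit of > 25 mg/kg in this assay, at which 2 of the 3 values shown sit.

The compounds shown leave open what dose of any of them gives the effect in this assay, and whether butyl in place of methoxy changes that dose at all.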